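The compounds below may be only part of what the source reports. "The series", "measured", "known", "first", "only" and "open" are said of these compounds alone.

Measured so far:
compound 1, `O=C(NC1CCN(Cc2ccc(Cl)cc2)CC1)c1cccc2ccccc12`: 43 nM
compound 2, `O=C(NC1CCN(Cc2cccc(Cl)c2)CC1)c1ccc2ccccc2c1`: 54 nM

Both compounds were tested in an assay on isolated protein for displacement of a labelled ligand from D(4) dopamine receptor (Homo sapiens); on this read-out lower numbers stand for stronger inhibition and higher numbers for weaker inhibition. In this assay compound 1 gives 43 nM and compound 2 gives 54 nM. These two numbers lie within the usual scatter of each other, so on the evidence at hand the two compounds cannot be told apart, and compound 2 simply shares the same region of the scale as compound 1.

Compound 3, `COc1cccc(CN2CCC(NC(=O)c3ccc4ccccc4c3)CC2)c1`, is not yet measured. It differs from compound 2 in one place: methoxy in place of chloro on an aromatic carbon. Among the compounds with values here, no pair of measured compounds shows this same change, so there is no measured step to lean on. Exchanging one small group for another at the same place usually gives a step no larger than the scatter, in either direction. For compound 3 the expected value in this assay is 70 nM, within a range from 25 nM to 200 nM. The step this estimate implies, a 1.3-fold higher number from compound 2 to compound 3 (0.11 log units; within the scatter), is expected to stay within the scatter.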

Compound 3, inhibition constant: 16 nM
Compound 3: middle estimate off by 4.4-fold (0.64 log units), on the high side; measured number outside the range, below it.
By their numbers in this assay, from the lowest: compound 3; then compounds 1 and 2 (each within the scatter of the next).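

In this assay changing 3-chlorobenzyl to 3-methoxybenzyl on the shared core gives a 3.4-fold lower number from compound 2 to compound 3 (0.53 log units; beyond the scatter) and so shows that this position responds to the choice of a small group. Within the data shown here, compound 1 and compound 2 differ in more than one place, so they could not show what a single exchange does here; this pair is the first to isolate one, and the change beyond the scatter favours methoxy over chloro. Nothing available explains why methoxy gives the lower number here.

Going by these compounds, it remains open whether the same exchange would give a similar step on the core of compound 1. Also open, on these data alone, is how other groups at this place would compare, such as a hydroxyl, an amine, a carboxylic acid or a longer ethoxy chain.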